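The source may hold more compounds than are shown below. What is called first, only, known or untested is meant among the compounds shown, and "the series" means these compounds.

Measured compounds:
Compound 1, `NCCNc1cc(N2CCN(c3ccccc3Cl)CC2)nc2ccccc12`, 20800 nM.
Compound 2, `NCCNc1cc(N2CCN(C(=O)C3(c4ccccc4)CC3)CC2)nc2ccccc12`, > 100000 nM (a limit of the assay, not a number).
Compound 3, `NCCNc1cc(N2CCN(c3ccc(Cl)cc3)CC2)nc2ccccc12`, 6600 nM.

In an ADME assay on HEp-2 cells (Homo sapiens) for cytotoxicity, read by CCK-8 assay, with a stated time of 6 days (on this read-out higher numbers stand for lower toxicity in this test and lower numbers for higher toxicity in this test), compound 3 stands lowest of the two numbers shown, its nearest neighbour being compound 1 with 20800 nM. Within the data shown here, the only step between measured compounds that differ in one place is a 3.2-fold lower number from compound 1 to compound 3 (0.50 log units; beyond the scatter), which moves a chlorine atom around the aromatic ring but keeps an aryl group on the ring nitrogen. Compound 2 gives only a limit in this assay, > 100000 nM, which is the limit of > 100000 nM in this assay, at which 1 of the 3 values shown sits.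

Compound 4, `NCCNc1cc(N2CCN(C(=O)C3CCCCC3)CC2)nc2ccccc12`, has not yet been measured. It differs from compound 3 in one place: cyclohexylcarbonyl in place of 4-chlorophenyl on an amine nitrogen in a ring. Among the measured compounds shown here, no measured step covers exactly this exchange of an aryl group for a carbonyl-linked ring. For the measured compounds named here, the one measured compound carrying a carbonyl on that ring nitrogen, compound 2, sits at the limit, while both aryl-bearing compounds give numbers. On that basis a large step towards a higher number is expected, beyond the scatter, and possibly again only a limit. The estimate means a step of a 9.1-fold higher number from compound 3 to compound 4 (0.96 log units; beyond the scatter). Compound 4 is therefore expected to give about 60000 nM, between 15000 nM and 150000 nM.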

Compound 4, half-maximal cytotoxic concentration: > 100000 nM
Compound 4 ended at the assay's limit; the forecaster's own chance of this, stated with the estimate: 55%; middle value at least 1.6-fold (0.22 log units) away from the limit.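

In this assay, exchanging a chlorophenyl group on the ring nitrogen for cyclohexylcarbonyl gives an at least 15-fold higher number from compound 3 to compound 4 (1.18 log units; beyond the scatter) for the 4-chlorophenyl case and an at least 4.8-fold higher number from compound 1 to compound 4 (0.68 log units; beyond the scatter) for the 2-chlorophenyl case, and both steps are minimum sizes, since the value of compound 4 is a limit of the assay and not a number. Until now, compound 2 was the only compound shown with a carbonyl on this nitrogen, but compound 4 shows that a different carbonyl-linked ring, one without an aromatic ring, also ends at the top of the range, while the two chlorophenyl compounds give numbers: the limit of > 100000 nM in this assay, at which 2 of the 4 values shown sit. Compound 2 and compound 4 both stand at that limit, so the step between them cannot be read and the cyclohexyl and 1-phenylcyclopropyl groups cannot be ranked.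

The compounds shown do not separate the part played by the carbonyl from the part played by losing the chlorophenyl group. A plain cyclohexyl group on the ring nitrogen, or a 4-chlorobenzoyl group there, would help to tell these two apart.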